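The source may hold more compounds than are shown below. What is called first, only, known or untested is meant among the compounds shown, and "the series" means these compounds.

Three compounds have been measured in an assay on isolated protein for inhibition of histone acetyltransferase p300 (Homo sapiens), with a stated time of 60 min; on this read-out higher numbers stand for weaker inhibition and lower numbers for stronger inhibition:

Compound 1 `COc1ccc(NC(=O)[C@H]2CCCN2C(=O)C2(c3cccc(Cl)c3)CCCC2)nc1` gives 2 nM.
Compound 2 `COc1ccc(NC(=O)[C@H]2CCN2C(=O)C2(c3ccc(Cl)cc3)CCCC2)cc1` gives 39.8 nM.
Compound 3 `COc1ccc(NC(=O)[C@H]2CCCCN2C(=O)C2(c3ccc(Cl)cc3)CCCC2)cc1` gives 5.01 nM.

On these numbers compound 1 stands lowest of the three, and so is the strongest inhibitor here. Compound 3 is nearest to it and compound 2 is furthest from it, and both gaps lie beyond the usual scatter of this assay.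

The next step starts from compound 1 and leads to compound 4 `O=C(Nc1ccc(O)cc1)[C@H]1CCCN1C(=O)C1(c2cccc(Cl)c2)CCCC1`, which has not yet been measured. Within the data shown here, the single change is 4-hydroxyphenyl in place of 5-methoxypyridin-2-yl on an amide-type nitrogen. Among the measured compounds shown here, no measured pair in this set shows this particular exchange, so there is no directly comparable step to lean on.

For compound 4 a modest weakening is expected, as the step of a 4.0-fold higher number from compound 1 to compound 4 (0.60 log units; beyond the scatter) from compound 1 describes. The estimate for compound 4 in this assay is 8 nM, with a range from 2 nM to 40 nM.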

Compound 4, half-maximal inhibitory concentration in the histone acetyltransferase p300 assay: 0.631 nM
Compound 4: the middle estimate sits 13-fold (1.10 log units) above what was measured; measured number below the stated range.
By their numbers in the histone acetyltransferase p300 assay, from the lowest: compound 4; then compound 1; then compound 3; then compound 2.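

In the histone acetyltransferase p300 assay, putting 4-hydroxyphenyl in place of 5-methoxypyridin-2-yl on the amide-type nitrogen gives a 3.2-fold lower number from compound 1 to compound 4 (0.50 log units; beyond the scatter). The earlier compounds shown here offered no single-change step at this place, and this one shows that a carbon-only ring carrying a hydrogen-bond donor is accepted here without any loss of inhibition. In a physicochemical assay for lipophilicity, at pH 7.4 (on this read-out higher numbers stand for higher lipophilicity and lower numbers for lower lipophilicity), compound 1 gives 6.8 and compound 4 gives 5.5. In the physicochemical assay the same exchange also lowers the number, so for this pair stronger inhibition does not require higher lipophilicity: the measured distribution coefficient of compound 1, 6.8, and of compound 4, 5.5, a number 1.30 log units lower (beyond the scatter)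

The exchange alters the ring and its oxygen-bearing group at once, so this single step cannot tell which part accounts for the gain. A 5-hydroxypyridin-2-yl group would help to separate the two, and a 4-aminophenyl group would test whether the hydroxyl can give way to an amine.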